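This account rests on a few compounds, and the source may have more. Where it says the series, first, only, none or still open, it means among the compounds named here.

Measured in a functional assay on MT4 cells (Homo sapiens) for inhibition; on this read-out higher numbers stand for weaker inhibition and lower numbers for stronger inhibition:
Compound 1 `C=C1[C@H](n2ccc(=O)[nH]c2=O)O[C@H](CO)[C@H]1O`: > 500000 nM (a limit)
Compound 2 `C=C1[C@H](n2cnc3c(N)nc(N)nc32)O[C@H](CO)[C@H]1O`: > 500000 nM (a limit)

Compound 2 has no exact number in this assay. Its > 500000 nM is a limit. Both measured compounds stand at the limit of > 500000 nM in this assay, at which 2 of the 2 values shown sit.

Compound 3 `C=C1[C@H](n2cnc3c(OC)nc(N)nc32)O[C@H](CO)[C@H]1O` carries methoxy in place of amino on an aromatic carbon, (methoxy in place of amino on an aromatic carbon). Going by the values given here, no measured step gives the size of this change, so no step beyond the scatter is expected in either direction. The expected change is a number no higher from compound 2 to compound 3 (the limit leaves the size open). Compound 3 is estimated at 500000 nM, with an expected range of 150000 nM to 1000000 nM.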

Compound 3, half-maximal inhibitory concentration: 180000 nM
Compound 3: the middle estimate sits 2.8-fold (0.44 log units) above what was measured, within the range that was stated.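

In this assay, methoxy in place of amino on an aromatic carbon gives an at least 2.7-fold lower number from compound 2 to compound 3 (0.44 log units; beyond the scatter). This makes compound 3 the only one of the three with an exact number, and it shows that a change at this position alone can move the read-out off the limit. Because compound 2 has only a limit, the step has a lower bound but no fixed size: the limit of > 500000 nM in this assay, at which 2 of the 3 values shown sit.

The compounds shown leave open whether ethoxy, a longer chain or a methylamino group on the same carbon would lower the number further.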